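A few compounds are considered here, and "the series" means these few. Any claim that something is new, unique, unknown or untested is made for them only; others in the source may bear on it.

Measured in a functional assay on MCF7 cells (Homo sapiens) for antiproliferative activity, read by MTT assay, with stated times of 24 h and 72 h; on this read-out lower numbers stand for stronger inhibition and higher numbers for weaker inhibition:
- compound 1 `COc1cc(N2C(=O)[C@@H](Oc3ccccc3)[C@H]2c2ccc(N(C)C)cc2)cc(OC)c1OC`: 31000 nM
- compound 2 `COc1cc(N2C(=O)[C@@H](Oc3ccccc3)[C@H]2c2ccc(C#N)cc2)cc(OC)c1OC`: 31600 nM
- compound 3 `COc1cc(N2C(=O)[C@@H](Oc3ccccc3)[C@H]2c2ccc(N=[N+]=[N-])cc2)cc(OC)c1OC`: 23000 nM

Compound 3 cannot be told apart from the other two. The steps to it are a 1.3-fold lower number from compound 1 to compound 3 (0.13 log units; within the scatter) and a 1.4-fold lower number from compound 2 to compound 3 (0.14 log units; within the scatter), and the remaining step is a 1.0-fold higher number from compound 1 to compound 2 (0.01 log units; within the scatter).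

Next comes compound 4 `COc1cc(N2C(=O)[C@@H](Oc3ccccc3)[C@H]2c2ccc(O)c(O)c2)cc(OC)c1OC`, with 3,4-dihydroxyphenyl in place of 4-azidophenyl on a saturated ring carbon. The three measured steps each swap a single group on this same aromatic ring, but none brings in hydroxy groups, so they offer only a loose guide. Little or no step beyond the scatter is expected in this assay, leaning toward a lower number, and the uncertainty is wide. The expected change is a 1.9-fold lower number from compound 3 to compound 4 (0.28 log units; within the scatter). For compound 4 the estimated value is 12000 nM, within an expected range of 1000 nM to 40000 nM.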

Compound 4, half-maximal inhibitory concentration: 4500 nM
For compound 4 the middle estimate is 2.7-fold (0.43 log units) above the measured one, and the stated range covers the measured number.
By their numbers in this assay, from the lowest: compound 4; then compounds 3, 1 and 2 (each within the scatter of the next).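

This position is not indifferent to change: in this assay the 3,4-dihydroxyphenyl group gives a 5.1-fold lower number from compound 3 to compound 4 (0.71 log units; beyond the scatter) and a 7.0-fold lower number from compound 2 to compound 4 (0.85 log units; beyond the scatter) and also a 6.9-fold lower number from compound 1 to compound 4 (0.84 log units; beyond the scatter) as the steps to it, while the steps among compounds 1, 2 and 3 all stayed within the scatter. The change replaces the whole aryl group, so these steps cannot credit either hydroxy group alone. Nothing available explains the gain. Going by these compounds, whether both hydroxy groups are needed remains open. A single hydroxy group, or methoxy groups in their place, would help separate these possibilities.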